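The compounds below may be only part of what the source reports. "The series", "measured", "known", "first", "only" and "open" are said of these compounds alone.

Of the compounds shown here, three have so far been measured in a functional assay on MCF7 cells (Homo sapiens) for antiproliferative activity, read by MTT assay, with a stated time of 72 h; on this read-out lower numbers stand for stronger inhibition and higher numbers for weaker inhibition. Compound 1 `Cc1cc(NCCN2CCN(C)CC2)nc2ccc(NC(=O)c3ccc(Cl)c(Cl)c3)cc12` gives 1700 nM, compound 2 `CCc1ccc(C(=O)Nc2ccc3nc(N4CCN(CC)CC4)cc(C)c3c2)cc1` gives 3060 nM, and compound 3 `Cc1cc(N(C)C)nc2ccc(NC(=O)c3ccc(Cl)c(Cl)c3)cc12` gives 33300 nM. Going by the values given here, the only step between compounds that differ in a single place, a 20-fold higher number from compound 1 to compound 3 (1.29 log units; beyond the scatter), concerns the amine attached to the shared core and leaves the amide side untouched. Compound 2 stands second highest of the three numbers: its nearest neighbour is compound 1, whose number lies within the scatter of that of compound 2, while compound 3 gives a number beyond the scatter above compound 2.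

Compound 4 `CCN1CCN(c2cc(C)c3cc(NC(=O)c4cccnc4)ccc3n2)CC1` has not yet been measured. Relative to compound 2 it carries pyridin-3-yl in place of 4-ethylphenyl on a carbonyl carbon. Among the compounds with values here, no measured step touches the group on the carbonyl carbon, so the one step that exists, on the amine side, offers no direct guide to this change, and the expectation rests only on the range that the measured compounds span around compound 2. Compound 4 is expected to give 5000 nM, with a range from 1500 nM to 20000 nM. The expected step, a 1.6-fold higher number from compound 2 to compound 4 (0.21 log units; within the scatter), is estimated to be modest and not clearly beyond the scatter.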

Compound 4, half-maximal inhibitory concentration: 26600 nM
Compound 4: the middle estimate sits 5.3-fold (0.73 log units) below what was measured, and the stated range ends below it.
By their numbers in this assay, from the lowest: compounds 1 and 2 (each within the scatter of the next); then compounds 4 and 3 (each within the scatter of the next).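

In this assay, going by these compounds alone, the amide side of the molecule proves to be a second place where the number moves, for an 8.7-fold higher number from compound 2 to compound 4 (0.94 log units; beyond the scatter) is the first measured change on the carbonyl carbon and lies beyond the scatter, so the amine attached to the shared core is not the only part that counts. Pyridin-3-yl in place of 4-ethylphenyl changes several things at once: the ring gains a nitrogen and a hydrogen-bond acceptor, the ethyl group goes, and the heavy-atom count falls from 8 to 6, and this one step cannot separate these differences. Nothing available explains why the number rises at this position.

Whether the ring nitrogen or the missing ethyl group accounts for the step remains open, and a plain phenyl on the carbonyl carbon, set against both compound 2 and compound 4, would divide the two. From the compounds shown here alone, it is also open whether the step carries over to another amine, such as the (2-(4-methylpiperazin-1-yl)ethyl)amino group of compound 1, as pyridin-3-yl is seen here only with the amine of compound 2.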